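The source may report more compounds than this note shows. Statements on the series, on what has been measured and on what is new or still open speak of the compounds shown alone.

Measured compounds:
Compound 1, `COC(OC)C1=C(C(=O)OC/C=C/c2ccccc2Cl)C(c2cccc(Cl)c2)C(C(=O)O)=C(C)N1`, in an assay on thoracic aorta for inhibition of Voltage-gated L-type calcium channel (Rattus norvegicus) (on this read-out higher numbers stand for weaker inhibition and lower numbers for stronger inhibition), gives 700 nM.
Compound 2, `COC(OC)C1=C(C(=O)OC/C=C/c2cccc(Cl)c2)C(c2cccc(Cl)c2)C(C(=O)O)=C(C)N1`, gives 1000 nM.
Compound 3, `COC(OC)C1=C(C(=O)OC/C=C/c2ccc(F)cc2)C(c2cccc(Cl)c2)C(C(=O)O)=C(C)N1`, gives 2000 nM.

Compound 3 carries the highest number of the three. Its nearest neighbour is compound 2, from which it is separated by a 2.0-fold higher number from compound 2 to compound 3 (0.30 log units; within the scatter), while against compound 1 the gap is a 2.9-fold higher number from compound 1 to compound 3 (0.46 log units; beyond the scatter). Compound 4, `COC(OC)C1=C(C(=O)OC/C=C/c2ccc(C(F)(F)F)cc2)C(c2cccc(Cl)c2)C(C(=O)O)=C(C)N1`, has not yet been measured. It differs from compound 3 by trifluoromethyl in place of fluoro on an aromatic carbon.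

Within the data shown here, none of the measured steps touches the same kind of change: each of them exchanges one substituted phenyl for another, whereas this one enlarges the group already standing on the phenyl. Those steps, a 1.4-fold higher number from compound 1 to compound 2 (0.15 log units; within the scatter), a 2.9-fold higher number from compound 1 to compound 3 (0.46 log units; beyond the scatter) and a 2.0-fold higher number from compound 2 to compound 3 (0.30 log units; within the scatter), were small to modest, and none of them gives a direct precedent for a bulkier group in this place. The step from compound 3 to compound 4 is therefore expected to stay small, most likely within the scatter and, if anything, towards a higher number. For compound 4 the estimate is 2500 nM, with a range from 1000 nM to 6500 nM, which corresponds to an expected step of a 1.3-fold higher number from compound 3 to compound 4 (0.10 log units; within the scatter).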

Compound 4, half-maximal inhibitory concentration: 3200 nM
For compound 4 the middle estimate is 1.3-fold (0.11 log units) below the measured one, within the range that was stated.
By their numbers in this assay, from the lowest: compounds 1, 2, 3 and 4 (each within the scatter of the next, the first and the last beyond it).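

In this assay, trifluoromethyl in place of fluoro on an aromatic carbon para to a large group gives a 1.6-fold higher number from compound 3 to compound 4 (0.20 log units; within the scatter) and so leaves no change that can be told from the scatter, although four heavy atoms enter where one leaves. Among these compounds, this is the first view of a larger group at this carbon, and it shows that, within this series, the position accepts that enlargement without a clear loss against the fluoro compound. The new compound does stand apart from the two chlorinated ones, with a 3.2-fold higher number from compound 2 to compound 4 (0.51 log units; beyond the scatter) and a 4.6-fold higher number from compound 1 to compound 4 (0.66 log units; beyond the scatter) both beyond the scatter, whereas a 2.0-fold higher number from compound 2 to compound 3 (0.30 log units; within the scatter) stays within it, and nothing shown here explains these differences.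

The compounds shown leave open how this carbon responds to a group of another kind, such as a methoxy, an amine or a nitrile, since only fluoro and trifluoromethyl appear there. They also leave open whether trifluoromethyl would give similar numbers on another carbon of the phenyl, or whether the same exchange would give a similar step if the carboxylic acid of the shared core were an ester.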